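This account rests on a few compounds, and the source may have more. Where it says the series, first, only, none or still open, it means among the compounds named here.

Compound 1 `COc1ccc(C(=O)N[C@H]2CCN(Cc3ccc(OCCCN(C)C)cc3)C2)cc1OC` carries a 3,4-dimethoxyphenyl on the carbonyl carbon of the shared core. In an assay on HEK293 cells for binding affinity to Urotensin-2 receptor (Homo sapiens), read by radioligand binding (a lower number here means a stronger inhibitor, a higher number a weaker inhibitor), compound 1 gives only a limit, < 10000 nM, so its place on the scale is not fixed by a number. Compound 2 `Cc1cc(C(=O)N[C@H]2CCN(Cc3ccc(OCCCN(C)C)cc3)C2)ccc1Br` bears a 4-bromo-3-methylphenyl on that carbonyl carbon, and in this assay compound 2 gives 631 nM. The step that the limit leaves unreadable from compound 1 to compound 2 therefore cannot be read in size, since the value of compound 1 rests at the limit described by the limit of < 10000 nM in this assay, at which 1 of the 2 values shown sits.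

Compound 3 `CN(C)CCCOc1ccc(CN2CC[C@H](NC(=O)c3ccc(C(F)(F)F)cc3)C2)cc1` is the next point on this route. The change from compound 1 is 4-(trifluoromethyl)phenyl in place of 3,4-dimethoxyphenyl on a carbonyl carbon; the group that enters and the group that leaves each amount to one six-membered aromatic ring of carbon only with the same count of heavy atoms, but the hydrogen-bond acceptors of the 3,4-dimethoxyphenyl are gone. Among the compounds with values here, the only measured step that bears on this exchange is the one from compound 1 to compound 2, and it is unreadable, so the direction from compound 1 can only be framed against the limit. Compound 3 is expected to land near compound 2, with an estimated step that the limit leaves unreadable from compound 1 to compound 3 and a value of 800 nM in this assay, within the range 200 nM to 4000 nM.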

Compound 3, inhibition constant: < 10000 nM
Compound 3 ended at the assay's limit (the forecaster's own chance of this, stated with the estimate: 15%); the middle value lies beyond the limit too.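

Compound 3 gives only a limit in this assay, < 10000 nM. No step from compound 1 or compound 2 to compound 3 can be read, with compound 1 and compound 3 both resting at that limit: the limit of < 10000 nM in this assay, at which 2 of the 3 values shown sit.

The compounds shown leave open where compound 1 and compound 3 actually lie on the scale, and so how 3,4-dimethoxyphenyl and 4-(trifluoromethyl)phenyl compare with 4-bromo-3-methylphenyl on the carbonyl carbon.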